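The source may report more compounds than this note shows. Statements on the series, on what has been measured and on what is new or still open speak of the compounds shown alone.

In a physicochemical assay for solubility, read by chemiluminescence, measured as kinetic solubility (a higher number here means a more soluble compound, a lower number a less soluble compound), compound 1 `CC(=O)NCc1cccc(Cn2nc(NS(=O)(=O)c3ccc(Cl)s3)c3c(C(C)O)cccc32)c1` gives >= 208 ug/mL, a limit of the assay rather than an exact number. Compound 2 `COc1cccc2c1c(NS(=O)(=O)c1ccc(Cl)s1)nn2Cc1cccc(CNC(=O)C2COC2)c1` gives >= 173 ug/mL, which is also a limit. Compound 2 therefore has no exact reading, and the two limits cannot be used to rank it against compound 1. Its true solubility is known only as far as its limit shows.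

Compound 3 `COc1cccc2c1c(NS(=O)(=O)c1ccc(Cl)s1)nn2Cc1cccc(CNC(=O)C2CCOCC2)c1` has not yet been measured. It keeps the shared core and the amide of compound 2 and changes in one place, with oxan-4-yl in place of oxetan-3-yl on a carbonyl carbon. The oxygen-containing ring thus grows from four-membered to six-membered, and the hydrogen-bond counts of the group stay the same.

Going by the values given here, no measured pair shows what this kind of change does, so the expectation is modest: little or no movement beyond the usual scatter. The estimate amounts to an expected at least 1.0-fold lower number from compound 2 to compound 3 (0.03 log units; that floor lies within the scatter), and this may well end in a limit again. For compound 3 the expected solubility is 160 ug/mL, with an estimated range of 60 ug/mL to 230 ug/mL.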

Compound 3, solubility: >= 193 ug/mL
Compound 3 was reported as a limit; the forecaster's own chance of this, stated with the estimate: 55%; middle value at least 1.2-fold (0.08 log units) from the limit.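

In this assay compound 3 gives >= 193 ug/mL, which is a limit. Going by these compounds alone, compound 2 also has only a limit, so no step from compound 2 to compound 3 can be read. The compounds shown leave open what exact solubility each has, and what oxan-4-yl in place of oxetan-3-yl on a carbonyl carbon does to that reading.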